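The source may hold more compounds than are shown below. What is called first, only, known or untested is meant among the compounds shown, and "the series" means these compounds.

Working notes on the thiosemicarbazone series.

Compound 1 `Fc1ccc(NC(=S)N/N=C\c2ccnc3ccccc23)cc1` was tested in an ADME assay on RAW264.7 cells (Mus musculus) for cytotoxicity, read by MTT assay, with a stated time of 48 h (on this read-out lower numbers stand for higher toxicity in this test and higher numbers for lower toxicity in this test), and gives 45900 nM. Compound 2 `S=C(N/N=C\c1ccnc2ccccc12)Nc1cccnc1`, which carries a pyridin-3-yl in place of the 4-fluorophenyl on the amide-type nitrogen, gives 91600 nM in this assay. Within the data shown here, the only measured step, a 2.0-fold higher number from compound 1 to compound 2 (0.30 log units; within the scatter), lies within the scatter, so no ordering of compound 1 and compound 2 can be read from these two numbers; compound 1 simply holds the lower of the two, with compound 2 the only neighbour.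

Compound 3 `Cc1ccc(NC(=S)N/N=C\c2ccnc3ccccc23)cc1` is the next member and differs from compound 1 by methyl in place of fluoro on an aromatic carbon. Among the measured compounds shown here, no measured step touches this position or this exchange; the one available step concerns the amide-type nitrogen and was itself within the scatter. There is therefore no basis in the series for expecting a shift beyond the scatter in this assay, and the step is estimated as a 1.1-fold higher number from compound 1 to compound 3 (0.04 log units; within the scatter). Compound 3 is expected to give about 50000 nM in this assay, within a range of 20000 nM to 125000 nM.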

Compound 3, half-maximal cytotoxic concentration: 50500 nM
Compound 3: the middle estimate sits 1.0-fold (0.00 log units) below what was measured; the range from low to high includes it.
By their numbers in this assay, from the lowest: compounds 1, 3 and 2 (each within the scatter of the next).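

Methyl in place of fluoro on an aromatic carbon, para to a large group, is the first exchange shown at this position, and in this assay it reads as a 1.1-fold higher number from compound 1 to compound 3 (0.04 log units; within the scatter) and so does not separate the 4-fluorophenyl from the 4-methylphenyl member. The second new comparison, 4-methylphenyl in place of pyridin-3-yl on the amide-type nitrogen, reads as a 1.8-fold lower number from compound 2 to compound 3 (0.26 log units; within the scatter) and adds to the earlier step on that nitrogen a further one that stays within the scatter, which leaves compound 1, compound 3 and compound 2 unresolved from one another in this test. No measurement is at hand that bears on what lies behind these small steps.

Still open, from the compounds shown here alone, is whether a group of another kind on this aromatic carbon, such as an amine, a carboxylic acid or a longer alkyl chain, would give a step beyond the scatter in this assay and so show that this position matters at all. Also open, going by these compounds, is whether any change to the shared core, rather than to the group on the amide-type nitrogen, would shift the number beyond the scatter.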